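Methyl in Place of Hydrogen on a Ring Oxygen

This account rests on a few compounds, and the source may have more. Where it says the series, first, only, none or still open, it means among the compounds named here.

Compound 1, `COc1ccc(-c2cn(-c3ccc(OC(F)(F)F)cc3)nn2)cc1O`, gives in a functional assay on MDA-MB-231 cells (Homo sapiens) for cytotoxicity, read by MTT assay (on this read-out lower numbers stand for stronger inhibition and higher numbers for weaker inhibition), only a limit of the assay, > 10000 nM.
Compound 2, `COc1ccc(-n2cc(-c3ccc(N)cc3)nn2)cc1O`, gives in this assay only a limit, > 10000 nM.
Compound 3, `COc1ccc(-c2cn(-c3ccc(OC(F)(F)F)cc3)nn2)cc1OC`, gives in this assay only a limit, > 1000 nM.

The change from compound 1 to compound 3 is methyl in place of hydrogen on an oxygen on an aromatic ring. Its size is not readable: a step that the two limits leave unreadable from compound 1 to compound 3, since one value sits at the limit of > 1000 nM in this assay, at which 1 of the 3 values shown sits, and the other at the limit of > 10000 nM in this assay, at which 2 of the 3 values shown sit. The difference between the core of compound 1 and the core of compound 2 is not broken down here.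

Compound 4, `COc1ccc(-n2cc(-c3ccc(N)cc3)nn2)cc1OC`, is not yet measured. It differs from compound 2 by methyl in place of hydrogen on an oxygen on an aromatic ring, the same change as from compound 1 to compound 3. Among the compounds with values here, because compound 2 itself sits at the limit of > 10000 nM in this assay, at which 2 of the 3 values shown sit, the step is expected to stay near zero, a step that the limit leaves unreadable from compound 2 to compound 4, with no measured step available to support a larger shift. Compound 4 is therefore expected to give 15000 nM in this assay, most likely again as a limit, with the range 5000 nM to 50000 nM as the estimate's spread.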

Compound 4, half-maximal inhibitory concentration: > 10000 nM
Compound 4: no number, only a limit (the forecaster's own chance of this, stated with the estimate: 80%); the middle value does not contradict the limit.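

No step can be read from compound 2 to compound 4, because both compounds give only a limit of the assay and no number: the limit of > 10000 nM in this assay, at which 3 of the 4 values shown sit.

The compounds shown leave open how large the change from hydroxy to methoxy is on either core in this assay, and where the actual values of these four compounds lie.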